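The source may report more compounds than this note shows. Statements on the series, on what has been measured and on what is new or still open speak of the compounds shown alone.

Compound 3 `O=C(Nc1nnc(-c2ccc(Cl)cc2)s1)c1ccccc1C(F)(F)F` stands at the weak end of what has been measured so far. In a functional assay on the whole organism (integument) for inhibition, with Chilo suppressalis as the target, read by scintillation counting, with a stated time of 72 h (a higher number here means a weaker inhibitor, a lower number a stronger inhibitor), compound 3 gives only a limit, > 16500 nM, so its true inhibitory concentration is not pinned down (the limit of > 16500 nM in this assay, at which 1 of the 3 values shown sits). Compound 4 `COc1ccccc1C(=O)Nc1nnc(-c2ccc(Cl)cc2)s1` has not yet been measured. The change from compound 3 to compound 4 is methoxy in place of trifluoromethyl on an aromatic carbon: the trifluoromethyl that sits ortho to a large group leaves, and a methoxy takes its place on the same aromatic carbon.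

For the measured compounds named here, two measured steps bear on this position. Compound 1 `O=C(Nc1nnc(-c2ccc(Cl)cc2)s1)c1ccccc1F` carries a fluoro there, and in this assay compound 1 gives 724 nM. Compound 2 `O=C(Nc1nnc(-c2ccc(Cl)cc2)s1)c1ccccc1Br` carries a bromo there. In this assay compound 2 gives only a limit, > 5010 nM (the limit of > 5010 nM in this assay, at which 1 of the 3 values shown sits). The step of an at least 6.9-fold higher number from compound 1 to compound 2 (0.84 log units; beyond the scatter) and the step of an at least 22-fold higher number from compound 1 to compound 3 (1.35 log units; beyond the scatter) both show that fluoro is the group that gives the strongest inhibition among the three, while the step that the two limits leave unreadable from compound 2 to compound 3 cannot be read. Methoxy has not been tried at this carbon, so the estimate for compound 4 is wide: it is expected to land between compound 1 and the limits, at about 2500 nM, with a range from 600 nM to 12000 nM. That expectation means a step of an at least 6.6-fold lower number from compound 3 to compound 4 (0.81 log units; beyond the scatter), read against a limit rather than a measured number.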

Compound 4, half-maximal inhibitory concentration: 53.7 nM
Compound 4: the middle estimate sits 47-fold (1.67 log units) above what was measured, outside the stated range (below it).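

The step of a 13-fold lower number from compound 1 to compound 4 (1.13 log units; beyond the scatter) in this assay makes methoxy the strongest of the four groups shown on this aromatic carbon, ahead of fluoro, which led among the three earlier groups, all of which carry halogen atoms. The step of an at least 300-fold lower number from compound 3 to compound 4 (2.48 log units; beyond the scatter) gives only a minimum size, as the value for compound 3 is a limit: the limit of > 16500 nM in this assay, at which 1 of the 4 values shown sits. The step of an at least 93-fold lower number from compound 2 to compound 4 (1.96 log units; beyond the scatter) is likewise only a minimum size, as the value for compound 2 is also a limit: the limit of > 5010 nM in this assay, at which 1 of the 4 values shown sits.

The compounds shown leave open whether the stronger inhibition follows the oxygen or the methyl part of methoxy, and a hydroxy group or a longer ethoxy chain on this carbon would help to separate the two. They also leave open whether methoxy gives the same gain on the other carbons of this ring, or when another group, such as an amine, replaces the chloro elsewhere in the shared core.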